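A fluorine joins the bromophenyl arm: compound 4 foreseen

The source may report more compounds than this note shows. Statements on the series, on what has been measured and on what is new or still open speak of the compounds shown alone.

Compound 2 `CCCn1c(=O)[nH]c2nc(-c3ccc(S(=O)(=O)N4CCN(Cc5cccc(Br)c5)CC4)cc3)[nH]c2c1=O` has been measured in an assay on CHO cells for displacement of a labelled ligand from adenosine receptor A1 (Homo sapiens), read by scintillation counting, with a stated time of 90 min, in the presence of a further agent that is not named here (a lower number here means a stronger inhibitor, a higher number a weaker inhibitor), where compound 2 gives 928 nM. Among the two numbers at hand it is the higher one, and its nearest neighbour is compound 1 `CCCn1c(=O)[nH]c2nc(-c3ccc(S(=O)(=O)N4CCN(Cc5cccc(C)c5)CC4)cc3)[nH]c2c1=O`, which in this assay gives 795 nM. Among the measured compounds shown here, the one readable step between them is a 1.2-fold higher number from compound 1 to compound 2 (0.07 log units; within the scatter). A third compound, compound 3 `CCCn1c(=O)c2[nH]c(-c3ccc(S(=O)(=O)N4CCN(c5ccc(Cl)cc5)CC4)cc3)nc2n(CC)c1=O`, differs from both in more than one place; in this assay compound 3 gives > 1000 nM, which is a limit of the assay and not a number. The same boundary, (the limit of > 1000 nM in this assay, at which 1 of the 3 values shown sits), lies close to where compound 2 stands.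

Compound 4 `CCCn1c(=O)[nH]c2nc(-c3ccc(S(=O)(=O)N4CCN(Cc5ccc(Br)c(F)c5)CC4)cc3)[nH]c2c1=O` is the untested member, and its change from compound 2 is 4-bromo-3-fluorophenyl in place of 3-bromophenyl on a saturated chain carbon bound to an amine nitrogen in a ring. For the measured compounds named here, the only measured step at that same place, the exchange from compound 1 to compound 2, stayed within the scatter, so for the entering 4-bromo-3-fluorophenyl no step beyond the scatter is expected in this assay in either direction. Compound 4 is therefore expected to give about 1000 nM, between 450 nM and 2300 nM, with a real chance that this assay returns only a limit for it. The step expected from compound 2 to compound 4 is a 1.1-fold higher number from compound 2 to compound 4 (0.03 log units; within the scatter).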

Compound 4, inhibition constant: 326 nM
Compound 4: the middle estimate sits 3.1-fold (0.49 log units) above what was measured, and the stated range ends above it.
By their numbers in this assay, from the lowest: compound 4; then compounds 1 and 2 (each within the scatter of the next). At a limit, above all of these: compound 3.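

The arm on the saturated chain carbon bound to an amine nitrogen in a ring proved able to move the number in this assay, with a 2.8-fold lower number from compound 2 to compound 4 (0.45 log units; beyond the scatter) and with a 2.4-fold lower number from compound 1 to compound 4 (0.39 log units; beyond the scatter). Among the compounds shown here, both steps are modest but lie beyond the scatter, whereas the only earlier exchange at this place, bromo in place of methyl, stayed within it, with a 1.2-fold higher number from compound 1 to compound 2 (0.07 log units; within the scatter). Nothing measured among the compounds shown accounts for the lower number of compound 4.

The compounds shown do not separate the entering fluorine from the changed place of the bromine, as neither a 4-bromophenyl nor a 3-fluorophenyl arm stands among them. As far as these compounds go, it also remains open how a nitrile or a methoxy group on this ring would read, and whether the same exchange would give a comparable step on the core of compound 3.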